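Removing the amide methyl from compound 2

The source may report more compounds than this note shows. Statements on the series, on what has been measured and on what is new or still open speak of the compounds shown alone.

Compound 1 `COc1cc(OCc2csc(-c3ccc(C(C)(C)O)cc3)n2)c2cc(-c3cn4nc(OC)sc4n3)oc2c1`: 1.15 h
Compound 2 `CNC(=O)c1ccc(-c2nc(COc3cc(OC)cc4oc(-c5cn6nc(OC)sc6n5)cc34)cs2)cc1`: 0.517 h

Among the measured compounds shown here, in an ADME assay on microsomes from liver (Rattus norvegicus) for metabolic stability (a lower number here means that the compound disappears faster, a higher number that the compound lasts longer), compound 2 has the lower of the two numbers measured so far. For the measured compounds named here, the only measured step, a 2.2-fold lower number from compound 1 to compound 2 (0.35 log units; beyond the scatter), is modest but lies beyond the scatter. It exchanged 1-hydroxy-1-methylethyl for methylcarbamoyl on an aromatic carbon.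

Compound 3 `COc1cc(OCc2csc(-c3ccc(C(N)=O)cc3)n2)c2cc(-c3cn4nc(OC)sc4n3)oc2c1` takes that methylcarbamoyl group one stage further. It differs from compound 2 by hydrogen in place of methyl on an amide-type nitrogen, with hydrogen in place of methyl on an amide-type nitrogen, so that methylcarbamoyl becomes carbamoyl. Going by the values given here, no measured step shows this exchange directly. The nearest guide is a 2.2-fold lower number from compound 1 to compound 2 (0.35 log units; beyond the scatter), which replaced a whole group and still moved the half-life only modestly. The present change is confined to the methyl, so a smaller shift is expected in this assay, with no clear direction and nothing beyond the scatter. The estimated change is a 1.2-fold higher number from compound 2 to compound 3 (0.06 log units; within the scatter). For compound 3, the expected half-life is 0.6 h, with an estimated range of 0.3 h to 1.2 h.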

Compound 3, half-life: 0.4 h
Compound 3: the middle estimate sits 1.5-fold (0.18 log units) above what was measured, and the stated range covers the measured number.
By their numbers in this assay, from the lowest: compounds 3 and 2 (each within the scatter of the next); then compound 1.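

In this assay, the amide methyl on its own carries little weight at this position: the step is small (a 1.3-fold lower number from compound 2 to compound 3 (0.11 log units; within the scatter)), and the methylcarbamoyl and carbamoyl forms cannot be told apart. The gap to the 1-hydroxy-1-methylethyl group remains beyond the scatter with the carbamoyl group in place (a 2.9-fold lower number from compound 1 to compound 3 (0.46 log units; beyond the scatter)), so among these three compounds both amides stand apart from compound 1, and none goes against that pattern. Nothing available here accounts for either step.

The compounds shown leave open whether an amide nitrogen carrying a longer chain, or a carboxylic acid or nitrile in place of the amide, would move the half-life beyond the scatter. They also leave open whether the higher number of compound 1 belongs to the 1-hydroxy-1-methylethyl group specifically or would also come with a smaller alcohol such as hydroxymethyl.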